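The source may hold more compounds than are shown below. What is called first, only, known or untested is meant among the compounds shown, and "the series" means these compounds.

Measured so far in an ADME assay on TERT-RPE1 cells (Homo sapiens) for cytotoxicity, read by MTT assay, with a stated time of 72 h; on this read-out lower numbers stand for stronger inhibition and higher numbers for weaker inhibition:
Compound 1 `COc1ccc(/C=C2/CN(C)/C(=N/c3ccc(Br)cc3)S2)cc1`: 61300 nM
Compound 2 `COc1ccc(/C=C2/CN(C)/C(=N/c3ccc([N+](=O)[O-])cc3)S2)cc1`: > 100000 nM

Compound 2 stands at a limit of the assay, > 100000 nM. The change to compound 3 `COc1ccc(/C=C2/CN(C)/C(=N/c3ccc(Cl)cc3)S2)cc1` is chloro in place of nitro on an aromatic carbon, para to a large group. Among the measured compounds shown here, one measured step bears on it: an at least 1.6-fold higher number from compound 1 to compound 2 (0.21 log units; that floor lies within the scatter), nitro in place of bromo on an aromatic carbon, and that floor lies within the scatter. On these data alone, the group that entered there leaves here, so the true size of that step remains unknown. A move to a lower number in this assay is nevertheless expected, with compound 3 expected to read near compound 1 at 61300 nM. The estimated step is an at least 1.6-fold lower number from compound 2 to compound 3 (0.22 log units; that floor lies within the scatter). For compound 3 the estimate is 60000 nM, with an expected range from 25000 nM to 100000 nM.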

Compound 3, half-maximal inhibitory concentration: 39600 nM
The estimate for compound 3 lay 1.5-fold (0.18 log units) above the measured number; measured number inside the range.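

At this position, para to a large group, this assay now gives a step beyond the scatter: chloro in place of nitro gives an at least 2.5-fold lower number from compound 2 to compound 3 (0.40 log units; beyond the scatter) where the earlier change between bromo and nitro gave only a floor within the scatter. That step is a floor and not a full size, because compound 2 stands at a limit: the limit of > 100000 nM in this assay, at which 1 of the 3 values shown sits. Chloro in place of bromo gives a 1.5-fold lower number from compound 1 to compound 3 (0.19 log units; within the scatter) and so does not separate the two halogens.

On these data alone, the true size of the step away from nitro remains open. Also open, as far as these compounds go, is how this read-out responds at the same position to a group other than a halogen or nitro, such as an amine or a carboxylic acid.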